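Hept-1-en-1-yl in place of 2-methoxyethynyl

A few compounds are considered here, and "the series" means these few. Any claim that something is new, unique, unknown or untested is made for them only; others in the source may bear on it.

For the measured compounds named here, in a functional assay on L1210 cells (Mus musculus) for inhibition (on this read-out higher numbers stand for weaker inhibition and lower numbers for stronger inhibition), compound 2 `COC#C[C@@]1(C)O[C@@H]2OC(=O)N(C(=O)CCl)[C@@H]2CC1=O` gives 74000 nM, the highest of the two numbers so far, while compound 1 `CCCCCCC[C@@]1(C)O[C@@H]2OC(=O)N(C(=O)CCl)[C@@H]2CC1=O` gives 28000 nM. Next in the series is compound 3 `CCCCC/C=C/[C@@]1(C)O[C@@H]2OC(=O)N(C(=O)CCl)[C@@H]2CC1=O`, with this change: hept-1-en-1-yl in place of 2-methoxyethynyl on a saturated ring carbon. In words, hept-1-en-1-yl stands in place of 2-methoxyethynyl on a saturated ring carbon. Going by the values given here, one measured step bears on this: a 2.6-fold higher number from compound 1 to compound 2 (0.42 log units; beyond the scatter), a modest step beyond the scatter, with 2-methoxyethynyl in place of heptyl on a saturated ring carbon. Heptyl in compound 1 goes with 28000 nM, and hept-1-en-1-yl is the nearer match to heptyl, so a step of similar size towards a lower number, meaning stronger inhibition, is expected in this assay. The estimated step is a 2.5-fold lower number from compound 2 to compound 3 (0.39 log units; beyond the scatter). For compound 3 the estimated value is 30000 nM, with an expected range of 14000 nM to 62000 nM.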

Compound 3, half-maximal inhibitory concentration: 81000 nM
For compound 3 the middle estimate is 2.7-fold (0.43 log units) below the measured one; measured number above the stated range.
By their numbers in this assay, from the lowest: compound 1; then compounds 2 and 3 (each within the scatter of the next).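

Read in this assay the unsaturated chain does not behave like its saturated counterpart: hept-1-en-1-yl in place of heptyl gives a 2.9-fold higher number from compound 1 to compound 3 (0.46 log units; beyond the scatter) as a modest loss of inhibition, while hept-1-en-1-yl in place of 2-methoxyethynyl gives a 1.1-fold higher number from compound 2 to compound 3 (0.04 log units; within the scatter) and leaves these two groups indistinguishable at this saturated ring carbon. Among the three groups, only the heptyl of compound 1 stands apart, as the strongest inhibitor of the set, so a seven-carbon chain as such does not recover its number. No measurement in hand accounts for the gap between heptyl and hept-1-en-1-yl. Open, from the compounds shown here alone, is whether a shorter chain such as butyl or a longer one such as decyl would take the number below that of compound 1. Also open, going by these compounds, is how a terminal amine or carboxylic acid on the heptyl chain would read in this assay at this position.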